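Notes on the aryl ether variation within the series

The compounds below may be only part of what the source reports. "The series", "measured", "known", "first", "only" and "open" are said of these compounds alone.

Measured so far:
compound 1 `CCOC(=O)[C@@H]1CC(=O)c2sccc2[C@H]1c1ccc(OC)cc1`: 26.2%
compound 2 `CCOC(=O)[C@@H]1CC(=O)c2sccc2[C@H]1c1ccc(OCC)cc1`: 29%

In a physicochemical assay, read by spectrophotometry, with a stated time of 20 min, tested at 100 ug/mL (a lower number here means a weaker effect, a higher number a stronger effect of the compound at the concentration tested), compound 1 gives 26.2%, and compound 2 gives 29%; the two values sit within the scatter of each other, the step being a number 2.8 percentage points higher from compound 1 to compound 2 (within the scatter). Compound 3 `CCOC(=O)[C@@H]1CC(=O)c2sccc2[C@H]1c1ccc(OC)c(OC)c1` differs from compound 1 by methoxy in place of hydrogen on an aromatic carbon. Among the compounds with values here, the single measured step concerns the chain carbon bound to the ring oxygen, not the aromatic ring itself, and stayed within the scatter, so no measured step bears directly on this change. No step beyond the scatter is therefore expected in this assay. Compound 3 is expected to give 28%, between 16% and 40%. This estimate means an expected step of a number 1.8 percentage points higher from compound 1 to compound 3 (within the scatter).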

Compound 3, a percentage reported as activity, at one concentration (the size of the read-out at that concentration, not a potency): 25.5%
Beside the measured number, compound 3's estimate is 2.5 percentage points above it; the range from low to high includes it.
By their numbers in this assay, from the lowest: compounds 3, 1 and 2 (each within the scatter of the next).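

Within the data shown here, this is the first measured change on the aromatic ring itself: methoxy in place of hydrogen on an aromatic carbon, ortho to a methoxy group, gives in this assay a number 0.7 percentage points lower from compound 1 to compound 3 (within the scatter). Substitution at this position, like the chain step on the ring oxygen, therefore shows no step beyond the scatter. Nothing at hand accounts for this reading.

On these data alone, whether an amine or a carboxylic acid at this aromatic carbon would produce a step beyond the scatter remains open. So does the outcome for a longer chain on the oxygen there.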